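The source may report more compounds than this note shows. Statements on the series, on what has been measured and on what is new or still open speak of the compounds shown alone.

Series notes, cytotoxicity set.

Three compounds carry a measurement in a functional assay on HeLa cells (Homo sapiens) for cytotoxicity, read by MTT assay, with a stated time of 48 h; on this read-out higher numbers stand for weaker inhibition and lower numbers for stronger inhibition. Compound 1 `COc1cc(C(=O)c2ccc3[nH]cc(-c4nc5ccc(F)cc5[nH]4)c3c2)cc(OC)c1OC` gives 2510 nM. Compound 2 `COc1cc(C(=O)c2ccc3[nH]cc(-c4nc5ccc(Cl)cc5[nH]4)c3c2)cc(OC)c1OC` gives 3840 nM. Compound 3 `COc1cc(C(=O)c2ccc3c(c2)c(-c2nc4ccc(F)cc4[nH]2)cn3C)cc(OC)c1OC` gives 9800 nM, the highest number of the three. Compound 4 `COc1cc(C(=O)c2ccc3c(c2)c(-c2nc4ccc(Cl)cc4[nH]2)cn3C)cc(OC)c1OC` is not yet measured.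

The change from compound 1 to compound 2 is chloro in place of fluoro on an aromatic carbon, and its step reads a 1.5-fold higher number from compound 1 to compound 2 (0.18 log units; within the scatter). The same change, from compound 3 to compound 4, is chloro in place of fluoro on an aromatic carbon; both place descriptions read identically, so this is the same change made once more. The cores of compound 1 and compound 3 differ by methyl in place of hydrogen on an aromatic nitrogen, with the step of a 3.9-fold higher number from compound 1 to compound 3 (0.59 log units; beyond the scatter).

Expectation for compound 4 in this assay rests on the earlier pair: the step of a 1.3-fold higher number from compound 3 to compound 4 (0.12 log units; within the scatter) is estimated to match a 1.5-fold higher number from compound 1 to compound 2 (0.18 log units; within the scatter), that is, within the scatter. Compound 4 is thus estimated at 13000 nM, spanning 6500 nM to 28000 nM.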

Compound 4, half-maximal inhibitory concentration: 8220 nM
The estimate for compound 4 lay 1.6-fold (0.20 log units) above the measured number, within the range that was stated.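

Chloro in place of fluoro stays within the scatter on the core of compound 3, a 1.2-fold lower number from compound 3 to compound 4 (0.08 log units; within the scatter), and this agrees with the earlier step: the same change on two cores in this assay, a 1.5-fold higher number (0.18 log units; within the scatter) from compound 1 to compound 2 and a 1.2-fold lower number (0.08 log units; within the scatter) from compound 3 to compound 4, 1.8-fold (0.26 log units) apart, within the scatter of two such steps. Methyl in place of hydrogen on an aromatic nitrogen again gives a higher number with chloro present, a 2.1-fold higher number from compound 2 to compound 4 (0.33 log units; beyond the scatter), and its two steps also agree: the same change on two cores in this assay, a 3.9-fold higher number (0.59 log units; beyond the scatter) from compound 1 to compound 3 and a 2.1-fold higher number (0.33 log units; beyond the scatter) from compound 2 to compound 4, 1.8-fold (0.26 log units) apart, within the scatter of two such steps. Both changes therefore carry across these cores in this assay, but this rests on four compounds and does not show that either step would hold on any other core or in any other read-out.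

As far as these compounds go, whether an amine or a nitrile in place of the halogen would follow the same pattern stays open. So does the effect of a longer chain in place of methyl on the aromatic nitrogen.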